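Branched enamide chains on the shared core in this assay

The compounds below may be only part of what the source reports. "The series", "measured", "known", "first", "only" and "open" are said of these compounds alone.

Measured compounds and their values:
compound 1 `COc1cc2ncnc(N3CCc4ccccc43)c2cc1NC(=O)/C=C/C(C)C` — 6530 nM
compound 2 `CC(C)=CC(=O)Nc1cc2c(N3CCc4ccccc43)ncnc2cc1O[C@@H]1CCOC1` — 4620 nM
compound 3 `CC/C=C/C(=O)Nc1cc2c(N3CCc4ccccc43)ncnc2cc1O[C@@H]1CCOC1` — 9590 nM

The read-out throughout is a functional assay on PC-3 cells (Homo sapiens) for antiproliferative activity, read by MTT assay, with a stated time of 72 h; on this read-out lower numbers stand for stronger inhibition and higher numbers for weaker inhibition. Compound 3 carries the highest of the three numbers: compound 1 sits within the scatter of it, while compound 2 lies beyond the scatter on the low side, as the step of a 2.1-fold higher number from compound 2 to compound 3 (0.32 log units; beyond the scatter) shows.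

Compound 4 `CC(C)/C=C/C(=O)Nc1cc2c(N3CCc4ccccc43)ncnc2cc1O[C@@H]1CCOC1` has not been measured. It differs from compound 3 by methyl in place of hydrogen on a saturated chain carbon bound to a double-bonded chain carbon and a saturated chain carbon, so the but-1-en-1-yl chain becomes 3-methylbut-1-en-1-yl; the ether group and the rest of the core stay the same.

For the measured compounds named here, one measured step bears on this change. The step of a 2.1-fold higher number from compound 2 to compound 3 (0.32 log units; beyond the scatter) went from a branched chain to an unbranched one, and the number rose. Compound 4 restores branching, one carbon further out than in compound 2. Compound 1 carries the same 3-methylbut-1-en-1-yl chain as compound 4 but a different ether, and its number is within the scatter of compound 3, so it gives no clear pull either way. Going by the values given here, a modest lowering of the number, about the size of the one measured step, is therefore expected as a 1.6-fold lower number from compound 3 to compound 4 (0.20 log units; within the scatter). For compound 4 the estimated value is 6000 nM, with a range from 2800 nM to 13000 nM.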

Compound 4, half-maximal inhibitory concentration: 11200 nM
Beside the measured number, compound 4's estimate is 1.9-fold (0.27 log units) below it; measured number inside the range.
By their numbers in this assay, from the lowest: compounds 2, 1, 3 and 4 (each within the scatter of the next, the first and the last beyond it).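

In this assay, adding methyl to the saturated chain carbon gives a 1.2-fold higher number from compound 3 to compound 4 (0.07 log units; within the scatter), so turning but-1-en-1-yl into 3-methylbut-1-en-1-yl has no readable effect at this position, and a branch on this carbon does not reproduce what compound 2 shows. The placement of the branch matters in this pair, with a 2.4-fold higher number from compound 2 to compound 4 (0.38 log units; beyond the scatter): the 2-methylprop-1-en-1-yl chain stands apart from the 3-methylbut-1-en-1-yl chain as well as from the unbranched chain, so branching as such does not track with the lower number, and compound 4 goes against any such pattern. With the 3-methylbut-1-en-1-yl chain held fixed, the ether change gives a 1.7-fold higher number from compound 1 to compound 4 (0.23 log units; within the scatter), so oxolan-3-yl and methyl on the oxygen cannot be told apart on this chain.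

No available evidence bears on why these chains differ. Still open, as far as these compounds go, are how the 2-methylprop-1-en-1-yl chain behaves with the methyl ether, and whether a longer chain or a chain ending in a dimethylamino group would separate further from these values.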